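Catechol diether amides: pyrazinyl in place of bromophenyl

A few compounds are considered here, and "the series" means these few. Any claim that something is new, unique, unknown or untested is made for them only; others in the source may bear on it.

Measured so far:
compound 1 `COc1ccc(C(=O)Nc2ccccc2Br)cc1OC1CCCC1` — 130 nM
compound 2 `COc1ccc(C(=O)Nc2ccccc2Cl)cc1OC(=O)c1ccccc1` — > 1000000 nM

For the measured compounds named here, compound 1 `COc1ccc(C(=O)Nc2ccccc2Br)cc1OC1CCCC1` is the only compound of the pair with a numerical result in an assay on isolated protein for inhibition of phosphodiesterase 4A (Sus scrofa) (a lower number here means a stronger inhibitor, a higher number a weaker inhibitor), where compound 1 gives 130 nM. Compound 2 `COc1ccc(C(=O)Nc2ccccc2Cl)cc1OC(=O)c1ccccc1` returns only a limit in this assay, > 1000000 nM, and that is all its entry says; this is the limit noted as the limit of > 1000000 nM in this assay, at which 1 of the 2 values shown sits. Going by the values given here, no step between two measured compounds is available, so the change to the unmeasured compound cannot be checked against an analogous one.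

Compound 3 `COc1ccc(C(=O)Nc2cnccn2)cc1OC1CCCC1` is obtained from compound 1 by the change (pyrazin-2-yl in place of 2-bromophenyl on an amide-type nitrogen). The shared core of compound 1 is kept; only the group on the amide-type nitrogen is exchanged. Among the compounds with values here, with no measured step of this kind to lean on, the expectation is a modest loss in this assay, a step from compound 1 to compound 3 of about a 2.7-fold higher number from compound 1 to compound 3 (0.43 log units; beyond the scatter), though the direction is uncertain and a result within the scatter would not be surprising. Compound 3 is therefore estimated at 350 nM, with a likely range from 60 nM to 2500 nM.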

Compound 3, half-maximal inhibitory concentration: 250 nM
For compound 3 the middle estimate is 1.4-fold (0.15 log units) above the measured one, within the range that was stated.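

In this assay, for the compounds shown here, the exchange of 2-bromophenyl for pyrazin-2-yl on the amide-type nitrogen gives the first readable step, a 1.9-fold higher number from compound 1 to compound 3 (0.28 log units; within the scatter), so the two compounds stand within the scatter of each other. At this position, then, a ring with 2 hetero atoms and 2 hydrogen-bond acceptors reads the same as a carbon-only ring carrying bromine, and neither that bromine nor the carbon-only ring is needed for a value in this range, at least for this single pair. Nothing measured here accounts for the two groups reading alike.

One exchange cannot show how far this tolerance reaches: a pyridinyl ring, a plain phenyl without bromine, or a non-aromatic group such as a piperidinyl amine or a carboxylic acid-bearing chain on the same nitrogen could read quite differently. Going by these compounds alone, compound 2 gives only a limit, > 1000000 nM, and differs from compound 1 in more than one place, so it yields no step and leaves the contribution of each of its differences open.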